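A few compounds are considered here, and "the series" means these few. Any claim that something is new, unique, unknown or untested is made for them only; others in the source may bear on it.

Compounds measured:
compound 1 `CN1CCC(CNS(=O)(=O)c2ccccc2Nc2cc(-c3ccc4ccn(C)c4c3)c3nccnc3c2)C1`: 11 nM
compound 2 `Cn1ccc2ccc(-c3cc(Nc4ccccc4S(=O)(=O)Nc4cncnc4)cc4nccnc34)cc21`: 1690 nM

For the measured compounds named here, in an assay for inhibition of 6-phosphofructo-2-kinase/fructose-2,6-bisphosphatase 3 (Homo sapiens), read by ADP-Glo, with a stated time of 2 h (on this read-out lower numbers stand for stronger inhibition and higher numbers for weaker inhibition), compound 1 gives the lowest of the two numbers, and the only measured step is a 150-fold higher number from compound 1 to compound 2 (2.19 log units; beyond the scatter), a large change at the sulfonamide nitrogen. Compound 3 `CN1CCC(NS(=O)(=O)c2ccccc2Nc2cc(-c3ccc4ccn(C)c4c3)c3nccnc3c2)C1` differs from compound 1 by 1-methylpyrrolidin-3-yl in place of (1-methylpyrrolidin-3-yl)methyl on a sulfonamide nitrogen. Going by the values given here, no measured step exchanges the two groups that differ here, so the large step from compound 1 to compound 2 gives only a loose guide. Since the group entering keeps the same ring and acceptor, a small step is expected, a 2.3-fold higher number from compound 1 to compound 3 (0.36 log units; beyond the scatter), toward a somewhat higher number. Compound 3 is therefore estimated at 25 nM, within 8 nM to 90 nM.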

Compound 3, half-maximal inhibitory concentration: 33 nM
For compound 3 the middle estimate is 1.3-fold (0.12 log units) below the measured one; measured number inside the range.
By their numbers in this assay, from the lowest: compound 1; then compound 3; then compound 2.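

Taking the substituent from (1-methylpyrrolidin-3-yl)methyl to 1-methylpyrrolidin-3-yl gives only a modest loss, a 3.0-fold higher number from compound 1 to compound 3 (0.48 log units; beyond the scatter), so the chain length at this sulfonamide nitrogen matters, but far less than the choice of group. The pyrimidin-5-yl group still falls well short of the shorter substituent, a 51-fold lower number from compound 2 to compound 3 (1.71 log units; beyond the scatter), so the large gap seen earlier does not rest on the chain carbon alone. No measured evidence is available to explain either step. From the compounds shown here alone, whether the ring nitrogen is needed remains open, as a cyclopentyl group would test that. A longer chain, such as 2-(1-methylpyrrolidin-3-yl)ethyl, could show whether the trend continues.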